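The source may hold more compounds than are shown below. What is called first, only, known or untested is meant among the compounds shown, and "the series" means these compounds.

The measured compounds: compound 1 `O=[N+]([O-])c1cc(-c2nc3ccc([N+](=O)[O-])cc3[nH]2)cc(-c2nc3ccc([N+](=O)[O-])cc3[nH]2)c1`, 13600 nM; compound 2 `FC(F)(F)c1ccc2nc(-c3cccc(-c4nc5ccc(C(F)(F)F)cc5[nH]4)c3)[nH]c2c1`, 8900 nM; compound 3 `COc1cc(-c2nc3ccc(C(F)(F)F)cc3[nH]2)cc(-c2nc3ccc(C(F)(F)F)cc3[nH]2)c1`, 8100 nM.

In a functional assay on A549 cells (Homo sapiens) for cytotoxicity, read by MTT assay, with a stated time of 48 h (on this read-out higher numbers stand for weaker inhibition and lower numbers for stronger inhibition), compound 3 gives the lowest of the three numbers, yet its gaps to compound 2 and to compound 1 lie within the scatter, so no order among them can be read. Compound 4 `O=[N+]([O-])c1cc(-c2nc3ccc(C(F)(F)F)cc3[nH]2)cc(-c2nc3ccc(C(F)(F)F)cc3[nH]2)c1` differs from compound 3 by nitro in place of methoxy on an aromatic carbon. Among the compounds with values here, the only measured step at that place, a 1.1-fold lower number from compound 2 to compound 3 (0.04 log units; within the scatter), was within the scatter; no measured step leads to a nitro group at that place. Compound 1 carries nitro at that place but differs elsewhere too, and its value sits in the same range as the others. Compound 4 is therefore expected to show no step beyond the scatter, a 1.2-fold higher number from compound 3 to compound 4 (0.07 log units; within the scatter). The estimate for compound 4 is 9500 nM, between 4000 nM and 22000 nM.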

Compound 4, half-maximal inhibitory concentration: 3800 nM
For compound 4 the middle estimate is 2.5-fold (0.40 log units) above the measured one; the whole stated range lies above it.
By their numbers in this assay, from the lowest: compound 4; then compounds 3, 2 and 1 (each within the scatter of the next).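

At this position, on an aromatic carbon meta to two large groups, nitro moves the number in this assay beyond the scatter, with a 2.1-fold lower number from compound 3 to compound 4 (0.33 log units; beyond the scatter) and a 2.3-fold lower number from compound 2 to compound 4 (0.37 log units; beyond the scatter) as modest steps, while methoxy did not, with a 1.1-fold lower number from compound 2 to compound 3 (0.04 log units; within the scatter) within the scatter. Within the data shown here, the position therefore does respond to what it carries, which the earlier compounds could not show. Nothing measured here explains the step.

On these data alone, whether an amine or a carboxylic acid at this position would lower the number as well stays open. So does whether nitro has the same effect when the trifluoromethyl groups are replaced, since compound 1 differs from compound 4 in more than one place.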